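Cytotoxicity notes on an oxazole amine series

The source may hold more compounds than are shown below. What is called first, only, known or untested is meant among the compounds shown, and "the series" means these compounds.

Measured compounds:
- compound 1 `Fc1cccc(F)c1Cc1cnc(Nc2ccc(-c3ccncc3)c(Cl)c2)o1`: 9300 nM
- compound 2 `Clc1cccc(Cl)c1Cc1nnc(Nc2ccc(COCc3ccoc3)cc2)o1`: 21000 nM
- compound 3 `Clc1cccc(Cl)c1Cc1nnc(Nc2ccc(COCc3cccnc3)cc2)o1`: 81000 nM

In an ADME assay on MT2 cells (Homo sapiens) for cytotoxicity, read by MTT assay (on this read-out higher numbers stand for lower toxicity in this test and lower numbers for higher toxicity in this test), compound 1 gives 9300 nM, the lowest of the three numbers. Compound 2 stands nearest to it with 21000 nM, compound 3 furthest with 81000 nM. Within the data shown here, the only step between compounds that differ in one place is a 3.9-fold higher number from compound 2 to compound 3 (0.59 log units; beyond the scatter); it concerns a different part of the molecule and a different pair of groups, so it does not bear on the change considered here.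

Compound 4 `Fc1cccc(F)c1Cc1cnc(Nc2ccc(Oc3ccncc3)c(Cl)c2)o1` is not yet measured in this assay. It differs from compound 1 by (pyridin-4-yl)oxy in place of pyridin-4-yl on an aromatic carbon. Among the measured compounds shown here, no measured pair in this set shows the effect of inserting an oxygen between the core and the pyridin-4-yl group, and the shared core with the chloro group and the difluoro benzyl part stays unchanged. For the measured compounds named here, the only guidance is the absence of a relevant step; an expectation of no change beyond the scatter is therefore the default, with the range widened because nothing in the data anchors this particular change.

The step from compound 1 to compound 4 is expected to be a 1.3-fold higher number from compound 1 to compound 4 (0.11 log units; within the scatter). Compound 4 is accordingly estimated at 12000 nM, within a range from 5000 nM to 30000 nM.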

Compound 4, half-maximal cytotoxic concentration: 21000 nM
Estimate against measurement, compound 4: 1.8-fold (0.24 log units) below; the range from low to high includes it.
By their numbers in this assay, from the lowest: compound 1; then compounds 2 and 4 (each within the scatter of the next); then compound 3.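

In this assay, among these compounds, the first direct reading at this position comes from a single change, on an aromatic carbon ortho to a chloro group and para to a large group: (pyridin-4-yl)oxy in place of pyridin-4-yl gives a 2.3-fold higher number from compound 1 to compound 4 (0.35 log units; beyond the scatter). The position is therefore not silent in this test, since keeping the pyridin-4-yl ring and adding an oxygen link on the shared core is enough to move the number beyond the scatter, modestly and towards lower toxicity in this test. Nothing at hand accounts for the shift, and no supporting measurement bears on it.

On these data alone, this one pair cannot separate the oxygen link itself from the greater reach of the ring, so it remains open whether a (pyridin-4-yl)amino or (pyridin-4-yl)methyl group on the same carbon would move the number in the same way. Also open, as far as these compounds go, are whether a plain phenoxy group would behave like (pyridin-4-yl)oxy, and whether the step would carry over to a compound with a hydrogen in place of the chloro group.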